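The compounds below may be only part of what the source reports. "The series", "measured", "known", "first", "only" and "open" are said of these compounds alone.

Measured compounds:
compound 1 `COc1cccc(N2C(=O)COc3ccc(-c4cnc(Cl)c(NS(=O)(=O)c5ccc(F)cc5)c4)cc32)c1` — > 40000 nM
compound 2 `COc1ccc(N2C(=O)COc3ccc(-c4cnc(OC)c(NS(=O)(=O)c5ccc(F)cc5)c4)cc32)cc1` — 8260 nM
compound 3 `CC(C)N1C(=O)COc2ccc(-c3cccc(NS(=O)(=O)c4ccc(F)cc4)c3)cc21` — 26000 nM

In a functional assay on MCF7 cells (Homo sapiens) for antiproliferative activity, read by MTT assay, with a stated time of 72 h (on this read-out higher numbers stand for weaker inhibition and lower numbers for stronger inhibition), compound 1 returns only a limit, > 40000 nM, not a number (the limit of > 40000 nM in this assay, at which 1 of the 3 values shown sits). Compound 2 gives 8260 nM in this assay, and compound 3 gives 26000 nM. Compound 4 `O=C1COc2ccc(-c3cnc(Cl)c(NS(=O)(=O)c4ccc(F)cc4)c3)cc2N1C1CC1` differs from compound 1 by one change: cyclopropyl in place of 3-methoxyphenyl on an amide-type nitrogen in a ring. Among the measured compounds shown here, no measured pair shows this step. Compound 3, which also carries a small alkyl on that amide nitrogen, gives 26000 nM, so the change is expected to bring at most a modest gain, possibly none beyond the scatter, and the step of an at least 1.3-fold lower number from compound 1 to compound 4 (0.12 log units; that floor lies within the scatter) is an estimate only. Compound 4 is expected to give about 30000 nM, within 10000 nM to 80000 nM.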

Compound 4, half-maximal inhibitory concentration: 16700 nM
Compound 4: the middle estimate sits 1.8-fold (0.25 log units) above what was measured, and the stated range covers the measured number.
By their numbers in this assay, from the lowest: compound 2; then compounds 4 and 3 (each within the scatter of the next). At a limit, above all of these: compound 1.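

In this assay, the amide-type nitrogen in the ring proves sensitive to its substituent: cyclopropyl in place of 3-methoxyphenyl brings an at least 2.3-fold lower number from compound 1 to compound 4 (0.37 log units; beyond the scatter). Among the compounds shown here, this is the first step at this position that can be read, and it replaces a limit for compound 1 with a number for compound 4. Only a floor can be given for its size because one end of the step is a limit: the limit of > 40000 nM in this assay, at which 1 of the 4 values shown sits.

As far as these compounds go, whether another small ring or an open-chain ethyl group would serve as well on the core of compound 4 stays open. So does the effect of an aminoethyl chain or a carboxylic acid at this nitrogen.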